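The compounds below may be only part of what the source reports. "The series", "measured", "known", "first", "only" and "open" are said of these compounds alone.

In a functional assay on HeLa cells (Homo sapiens) for inhibition, with a stated time of 48 h, tested at 50 uM (on this read-out lower numbers stand for less inhibition of growth and higher numbers for more inhibition of growth at the one concentration tested), compound 1 (`C=C[C@@](C)(/C=C/c1ccc(O)cc1)CC/C=C(/C)C=O`) gives 40% and compound 2 (`COc1ccccc1/C=C/[C@@](C)(/C=C/c1ccc(O)cc1)CCC=C(C)C`) gives 50% with the two values within the scatter of each other, which places compound 2 level with compound 1. Compound 3 (`CC(C)=CCC[C@@](C)(/C=C/c1ccc(N)cc1)/C=C/c1ccc(O)cc1`) has 4-aminophenyl in place of 2-methoxyphenyl on a double-bonded chain carbon bound to a double-bonded chain carbon. Among the compounds with values here, no measured pair shows this change, so no step beyond the scatter is expected in this assay for it. The expected step of a number 5 percentage points lower from compound 2 to compound 3 (within the scatter) stays within the scatter. Compound 3 is expected at 45% (estimated range 25% to 65%).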

Compound 3, percent growth inhibition at one concentration: 27%
Compound 3: middle estimate off by 18 percentage points, on the high side, within the range that was stated.
By their numbers in this assay, from the lowest: compound 3; then compounds 1 and 2 (each within the scatter of the next).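

In this assay, 4-aminophenyl in place of 2-methoxyphenyl on a double-bonded chain carbon bound to a double-bonded chain carbon gives a number 23 percentage points lower from compound 2 to compound 3 (beyond the scatter) and so shows that the group held at this position can change growth inhibition, which compounds 1 and 2 could not show. Nothing shown gives a reason for this step. From the compounds shown here alone, the two groups differ in both substituent and ring numbering, so which of these carries the step stays open. 4-Methoxyphenyl or 2-aminophenyl at this position would separate the two.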